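The source may hold more compounds than are shown below. What is called first, only, known or untested is meant among the compounds shown, and "the series" means these compounds.

Measured compounds in a functional assay on A549 cells (Homo sapiens) for antiproliferative activity, read by MTT assay, with a stated time of 48 h; on this read-out lower numbers stand for stronger inhibition and higher numbers for weaker inhibition:
compound 1 `N#CC1=C(N)Oc2c(N)cc3nc4ccccc4nc3c2C12C(=O)N(Cc1cnnn1-c1ccccc1Cl)c1ccccc12`, 29800 nM
compound 2 `N#CC1=C(N)Oc2c(N)cc3nc4ccccc4nc3c2C12C(=O)N(Cc1cnnn1-c1cccc(C(F)(F)F)c1)c1ccccc12`, 5400 nM
compound 3 `Cc1cc(C)cc(-n2nncc2CN2C(=O)C3(C(C#N)=C(N)Oc4c(N)cc5nc6ccccc6nc5c43)c3ccccc32)c1`, 31200 nM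

Compound 3 gives the highest of the three numbers, though its gap to compound 1 is within the scatter; only compound 2 sits apart, a 5.8-fold higher number from compound 2 to compound 3 (0.76 log units; beyond the scatter). Compound 4 `Cc1cc(C)c(-n2nncc2CN2C(=O)C3(C(C#N)=C(N)Oc4c(N)cc5nc6ccccc6nc5c43)c3ccccc32)c(C)c1` differs from compound 3 by 2,4,6-trimethylphenyl in place of 3,5-dimethylphenyl on an aromatic nitrogen. Every measured step is a swap of the aryl on the aromatic nitrogen: a 5.5-fold lower number from compound 1 to compound 2 (0.74 log units; beyond the scatter) and a 1.0-fold higher number from compound 1 to compound 3 (0.02 log units; within the scatter). Only the trifluoromethyl-bearing aryl moved the number beyond the scatter; the chloro- and dimethyl-bearing aryls sit together. As 2,4,6-trimethylphenyl is again a methyl-bearing aryl, no step beyond the scatter is expected in this assay, a 1.0-fold lower number from compound 3 to compound 4 (0.02 log units; within the scatter). Compound 4 is therefore estimated at 30000 nM, within 12000 nM to 75000 nM.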

Compound 4, half-maximal inhibitory concentration: 12700 nM
Compound 4: the middle estimate sits 2.4-fold (0.37 log units) above what was measured; low and high end bracket the measured number.
By their numbers in this assay, from the lowest: compound 2; then compound 4; then compounds 1 and 3 (each within the scatter of the next).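

In this assay the methyl-bearing aryls no longer sit together, with a 2.5-fold lower number from compound 3 to compound 4 (0.39 log units; beyond the scatter) showing that a change beyond the scatter at this aromatic nitrogen does not require trifluoromethyl. The 2,4,6-trimethylphenyl group gives a 2.3-fold lower number from compound 1 to compound 4 (0.37 log units; beyond the scatter) and so separates from 2-chlorophenyl, while a 2.4-fold higher number from compound 2 to compound 4 (0.37 log units; beyond the scatter) leaves it short of 3-(trifluoromethyl)phenyl. Nothing available here explains these shifts.

Open, from the compounds shown here alone, is whether the added methyl or the altered methyl arrangement accounts for the step. Also open, going by these compounds, is how an amine or a carboxylic acid on this aryl would read.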